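Cyclobutyl amide to butyl urea on the benzothiazole series

The source may hold more compounds than are shown below. What is called first, only, known or untested is meant among the compounds shown, and "the series" means these compounds.

Measured so far:
compound 1, `O=C(Nc1nc2ccc(N/C(S)=N/C3=CC4OCCOC4C=C3)cc2s1)C1CCCCC1`, 1.6 ug/mL
compound 2, `O=C(Nc1ccc2nc(NC(=O)C3CCC3)sc2c1)c1c(Cl)cccc1Cl`, 0.013 ug/mL

Two compounds have been run in a functional assay on WI-38 VA13 cells (Homo sapiens) for cytotoxicity; on this read-out lower numbers stand for an effect already at smaller amounts and higher numbers for an effect only at larger amounts of compound. Compound 2 gives the lower of the two numbers, 0.013 ug/mL, and compound 1, at 1.6 ug/mL, sits far above it, a gap well beyond the scatter of repeat runs. Compound 2 is therefore the reference point for the next step.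

Compound 3, `CCCCNC(=O)Nc1nc2ccc(NC(=O)c3c(Cl)cccc3Cl)cc2s1`, keeps the shared core of compound 2 and its dichlorobenzoyl amide unchanged; the one difference is butylamino in place of cyclobutyl on a carbonyl carbon. Cut one bond further out, the change reads (cyclobutylcarbonyl)amino to (butylcarbamoyl)amino.

Within the data shown here, no measured pair shows this exact change, so the size of the step rests on expectation alone. A small move toward a higher number in this assay seems most likely, possibly not beyond the scatter. Compound 3 is estimated at 0.04 ug/mL, within a range of 0.005 ug/mL to 0.4 ug/mL, which means an expected step of a 3.1-fold higher number from compound 2 to compound 3 (0.49 log units; beyond the scatter).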

Compound 3, half-maximal effective concentration: 0.028 ug/mL
Beside the measured number, compound 3's estimate is 1.4-fold (0.15 log units) above it, and the stated range covers the measured number.
By their numbers in this assay, from the lowest: compound 2; then compound 3; then compound 1.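

In this assay, among these compounds, butylamino in place of cyclobutyl on a carbonyl carbon gives a 2.2-fold higher number from compound 2 to compound 3 (0.33 log units; beyond the scatter), a modest step and the first reading of a change at this position with the rest of the molecule held constant. The position accepts a move from amide to butyl urea, with the four-membered ring gone and one hydrogen-bond donor added, at the cost of only this small shift, and compound 3 still gives 0.028 ug/mL. Nothing measured here explains the step, so the result stands as an observation on this one pair.

Among the compounds shown here, the single step combines two differences, the loss of the ring and the entry of the nitrogen, and their separate contributions cannot be read from it; a straight-chain pentanoyl amide or a cyclobutylamino urea on the same core would pull them apart. From the compounds shown here alone, how far this position stretches also remains open, for example to a longer chain such as hexylamino, or to a butyl chain ending in an amine or a carboxylic acid.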